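Isobutyl to isopropyl on the chain carbon of compound 3

The compounds below may be only part of what the source reports. "The series", "measured", "known", "first", "only" and "open" are said of these compounds alone.

Among the measured compounds shown here, compound 3 `CC(=O)c1ccc(NC(=O)C(CC(C)C)N(C(=O)c2ccccc2)S(=O)(=O)c2ccccc2)cc1` gives 33.7% in a functional assay for inhibition, read by spectrophotometry, with a stated time of 20 min, tested at 2 mg/mL (on this read-out higher numbers stand for a stronger effect at the one concentration tested and lower numbers for a weaker effect), which places it second highest of the three numbers measured so far. For the measured compounds named here, compound 2 `CC(=O)c1ccc(NC(=O)CN(C(=O)c2ccccc2)S(=O)(=O)c2ccccc2)cc1` gives 40.5% in this assay, and compound 1 `CC(=O)c1ccc(NC(=O)C(C(C)C)N(C(=O)c2ccccc2)S(=O)(=O)c2ccc(C)cc2)cc1` gives 22.7% in this assay, the only number that stands beyond the scatter away from compound 3. Compound 4 `CC(=O)c1ccc(NC(=O)C(C(C)C)N(C(=O)c2ccccc2)S(=O)(=O)c2ccccc2)cc1` differs from compound 3 by isopropyl in place of isobutyl on a saturated chain carbon bound to an amide-type nitrogen and a carbonyl carbon. Going by the values given here, only one measured step touches this position: a number 6.8 percentage points lower from compound 2 to compound 3 (within the scatter), where hydrogen became isobutyl without moving the read-out beyond the scatter. Compound 1 also carries isopropyl on the same carbon, but with a different sulfonyl ring, and in this assay compound 1 gives 22.7%. Among the compounds with values here, since the one relevant step stayed within the scatter, the step from compound 3 to compound 4 is expected to be a number 4.7 percentage points lower from compound 3 to compound 4 (within the scatter), small and not beyond the scatter, with a slight lean downward. Compound 4 is therefore estimated to give 29% in this assay, within a range from 16% to 42%.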

Compound 4, a percentage reported as inhibition, at one concentration (the size of the read-out at that concentration, not a potency): 41.3%
Beside the measured number, compound 4's estimate is 12.3 percentage points below it; low and high end bracket the measured number.
By their numbers in this assay, from the lowest: compound 1; then compounds 3, 2 and 4 (each within the scatter of the next).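

In this assay, the chain carbon bound to an amide-type nitrogen and a carbonyl carbon now carries hydrogen, isobutyl or isopropyl without a step beyond the scatter: isopropyl in place of isobutyl gives a number 7.6 percentage points higher from compound 3 to compound 4 (within the scatter), and isopropyl in place of hydrogen gives a number 0.8 percentage points higher from compound 2 to compound 4 (within the scatter). Among the compounds shown here, the one step beyond the scatter lies elsewhere, on an aromatic carbon, where hydrogen in place of methyl gives a number 18.6 percentage points higher from compound 1 to compound 4 (beyond the scatter), so with isopropyl held constant the low number of compound 1 goes with the methyl and not with the isopropyl. Nothing available explains either the flat chain position or the step at the aromatic carbon.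

On these data alone, whether an amine or a longer chain on the chain carbon would also stay within the scatter remains open. So does whether methoxy or chlorine on the aromatic carbon would act as methyl does, and whether the methyl step holds with isobutyl or hydrogen on the chain carbon.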